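The source may report more compounds than this note shows. Statements on the series, on what has been measured and on what is new or still open speak of the compounds shown alone.

Working notes on the aryl amides built on the core of compound 1 `Cc1cc(-c2ccccc2)nc2nc(NC(=O)c3ccccc3F)nn12`. In an ADME assay on MDCK cells (Canis lupus familiaris) for cytotoxicity, read by MTT assay, with a stated time of 48 h (on this read-out lower numbers stand for higher toxicity in this test and higher numbers for lower toxicity in this test), compound 1 gives > 250000 nM, which is a limit and not a number. Compound 2 `Cc1cc(-c2ccccc2)nc2nc(NC(=O)c3ccc(N)cc3)nn12` gives > 250000 nM, also a limit. Compound 3 `COc1ccc(C(=O)Nc2nc3nc(-c4ccccc4)cc(C)n3n2)cc1` gives > 250000 nM, again a limit. Compound 3 therefore has no numerical position in the series, and the same holds for the other two: the limit of > 250000 nM in this assay, at which 3 of the 3 values shown sit.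

The next step leads to compound 4 `Cc1cc(-c2ccccc2)nc2nc(NC(=O)c3ccc(O)c(O)c3)nn12`, with 3,4-dihydroxyphenyl in place of 4-methoxyphenyl on a carbonyl carbon.

Within the data shown here, three measured steps bear on this change: a step that the two limits leave unreadable from compound 1 to compound 2, a step that the two limits leave unreadable from compound 1 to compound 3 and a step that the two limits leave unreadable from compound 2 to compound 3. None has a readable size, and none of them involves the 3,4-dihydroxyphenyl group. All three compounds nevertheless sit at the same limit, so no step beyond the scatter is the working expectation in this assay. A fall toward higher toxicity cannot be excluded for a group new to the series, so the range is kept wider on the lower side. The expected change is an at least 1.2-fold lower number from compound 3 to compound 4 (0.09 log units; that floor lies within the scatter). For compound 4 the estimated value is 200000 nM, with an expected range from 80000 nM to 250000 nM.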

Compound 4, half-maximal cytotoxic concentration: 112000 nM
Estimate against measurement, compound 4: 1.8-fold (0.25 log units) above, within the range that was stated.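

In this assay, the aryl group on the carbonyl carbon now produces a readable change: an at least 2.2-fold lower number from compound 3 to compound 4 (0.34 log units; beyond the scatter), an at least 2.2-fold lower number from compound 2 to compound 4 (0.34 log units; beyond the scatter) and an at least 2.2-fold lower number from compound 1 to compound 4 (0.34 log units; beyond the scatter). Among these compounds, the steps among compounds 1, 2 and 3 cannot be read, so 2-fluorophenyl, 4-aminophenyl and 4-methoxyphenyl cannot be ranked against one another, whereas 3,4-dihydroxyphenyl is the first group here to move the read-out toward higher toxicity in this test. Each of the new steps starts from a limit and so gives only a floor for its size, and compound 4 is the one amide in the series with a number rather than a limit: the limit of > 250000 nM in this assay, at which 3 of the 4 values shown sit.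

The compounds shown leave open whether the change needs both hydroxy groups or whether a phenyl carrying a single hydroxy group would give the same shift, and whether two methoxy groups in their place would return the read-out to the limit. Also open, on these data alone, is how a carboxylic acid on the same phenyl would behave, and whether the step persists when the methyl or phenyl on the shared core is replaced.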